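The source may report more compounds than this note shows. Statements on the series, on what has been measured and on what is new or still open speak of the compounds shown alone.

Compound 1 `O[C@H](COCCOC[C@@H](O)Cc1cn(-c2cccs2)nn1)Cc1ccc(-c2ccccc2)cc1`: 33400 nM in a functional assay on SGC-7901 cells (Homo sapiens) for inhibition, read by MTT assay, with a stated time of 72 h; on this read-out higher numbers stand for weaker inhibition of growth and lower numbers for stronger inhibition of growth.
Compound 2 `O[C@H](COCCOC[C@@H](O)Cc1cn(-c2cncnc2)nn1)Cc1ccc(-c2ccccc2)cc1`: only a limit in this assay, > 100000 nM.
Compound 3 `O=c1[nH]c2ccc(-n3cc(C[C@H](O)COCCOC[C@@H](O)Cc4ccc(-c5ccccc5)cc4)nn3)cc2s1`: 10500 nM in this assay.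

Compound 3 has the lowest number of the two measured in this assay; the nearest is compound 1, with a 3.2-fold lower number from compound 1 to compound 3 (0.50 log units; beyond the scatter). Compound 2 sits at the limit of > 100000 nM in this assay, at which 1 of the 3 values shown sits, so an at least 9.5-fold lower number from compound 2 to compound 3 (0.97 log units; beyond the scatter) is a lower bound. Compound 4 `O[C@H](COCCOC[C@@H](O)Cc1cn(-c2ccc3c(c2)OCCO3)nn1)Cc1ccc(-c2ccccc2)cc1` differs from compound 3 by a group of 10 heavy atoms (8 carbon, 2 oxygen; one six-membered non-aromatic ring with 2 hetero atoms, one six-membered aromatic ring of carbon only) in place of a group of 10 heavy atoms (7 carbon, 1 nitrogen, 1 oxygen, 1 sulfur; one five-membered aromatic ring with 2 hetero atoms, one six-membered aromatic ring of carbon only), on an aromatic nitrogen. Both measured steps change the group on the same aromatic nitrogen, and both favour the bicyclic group of compound 3 over a single ring. Compound 4 keeps a bicyclic group, so a change smaller than a 3.2-fold lower number from compound 1 to compound 3 (0.50 log units; beyond the scatter) is expected, most likely a modest rise, a 1.9-fold higher number from compound 3 to compound 4 (0.28 log units; within the scatter). Compound 4 is therefore estimated at 20000 nM, between 7000 nM and 60000 nM.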

Compound 4, concentration for 50% growth inhibition: 6400 nM
Estimate against measurement, compound 4: 3.1-fold (0.49 log units) above, outside the stated range (below it).
By their numbers in this assay, from the lowest: compounds 4 and 3 (each within the scatter of the next); then compound 1. At a limit, above all of these: compound 2.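

With 2,3-dihydro-1,4-benzodioxin-6-yl on the aromatic nitrogen, a 1.6-fold lower number from compound 3 to compound 4 (0.22 log units; within the scatter) in this assay shows that a second bicyclic group, with 0 hydrogen-bond donors, leaves the read-out unresolved from that of the earlier bicyclic group. The advantage over single rings holds for this new group as well, with a 5.2-fold lower number from compound 1 to compound 4 (0.72 log units; beyond the scatter) and an at least 15-fold lower number from compound 2 to compound 4 (1.19 log units; beyond the scatter), the second step being only a lower bound. Compound 2 stands at a limit: the limit of > 100000 nM in this assay, at which 1 of the 4 values shown sits.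

The compounds shown leave open whether a plain phenyl, or a phenyl carrying an amine or a carboxylic acid, on this aromatic nitrogen would match the bicyclic groups.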